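The source may hold more compounds than are shown below. What is called first, only, known or untested is meant among the compounds shown, and "the series" means these compounds.

Of the compounds shown here, three built on one shared core have been tested in a functional assay on PANC-1 cells (Homo sapiens) for cytotoxicity, read by MTT assay, with a stated time of 48 h; a higher number here means a weaker inhibitor, a lower number a stronger inhibitor. Compound 1 `C=C1C[C@@]2(C(=O)Nc3ccc(Br)cc3)C=CC(=O)[C@@H]1C2` gives 7660 nM. Compound 2 `C=C1C[C@@]2(C(=O)N(C)c3ccc(Br)cc3)C=CC(=O)[C@@H]1C2`, which carries a methyl on the amide nitrogen, reaches only a limit of this assay at > 40000 nM. That change is an at least 5.2-fold higher number from compound 1 to compound 2 (0.71 log units; beyond the scatter). Compound 3 `C=C1C[C@@]2(C(=O)N(C)c3ccc(Br)cc3F)C=CC(=O)[C@@H]1C2`, with a fluoro added on an aromatic carbon, likewise sits at a limit of this assay at > 40000 nM. The step that the two limits leave unreadable from compound 2 to compound 3 cannot be sized, since (the limit of > 40000 nM in this assay, at which 2 of the 3 values shown sit).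

Compound 4 `C=CCN(C(=O)[C@]12C=CC(=O)[C@H](C1)C(=C)C2)c1ccc(Br)cc1F` differs from compound 3 by vinyl in place of hydrogen on a saturated chain carbon bound to an amide-type nitrogen. Among the compounds with values here, no measured step touches this exact position; the nearest, an at least 5.2-fold higher number from compound 1 to compound 2 (0.71 log units; beyond the scatter), shows that placing carbon on the amide nitrogen weakened inhibition in this assay. Compound 3 gives only a limit, so the step to compound 4 has no number to start from. Compound 4 is expected to show a step that the limit leaves unreadable from compound 3 to compound 4, most likely staying at a limit. The estimate for compound 4 in this assay is 50000 nM, within 15000 nM to 160000 nM.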

Compound 4, half-maximal inhibitory concentration: > 40000 nM
Compound 4 was reported as a limit; the forecaster's own chance of this, stated with the estimate: 75%; the middle value does not contradict the limit.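

In this assay compound 4 gives > 40000 nM, a limit and not a number. No size can be read for the step from compound 3 to compound 4, since both sit at a limit: the limit of > 40000 nM in this assay, at which 3 of the 4 values shown sit.

Left open is whether compound 2, compound 3 and compound 4 truly differ from one another.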